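Methyl to chloro on the aryl ring of compound 1

This account rests on a few compounds, and the source may have more. Where it says the series, first, only, none or still open, it means among the compounds named here.

The series shares one core with a nitro group and varies the aryl ring attached to it. Activity is followed in a functional assay for antagonist activity at Neuropeptides B/W receptor type 1 (Homo sapiens), read by cAMP accumulation; on this read-out higher numbers stand for weaker inhibition and lower numbers for stronger inhibition. Compound 1 `Cc1ccc(-c2nc3cc([N+](=O)[O-])ccc3[nH]2)cc1C` gives 1380 nM in this assay. Compound 2 `CC(=O)c1ccc(-c2nc3cc([N+](=O)[O-])ccc3[nH]2)cc1` gives 9320 nM. Compound 3 `O=[N+]([O-])c1ccc2[nH]c(-c3c(Cl)cc(Cl)cc3I)nc2c1` gives 205 nM. On the three numbers compound 1 stands second highest: compound 3 is the nearest with a lower number, beyond the scatter, and compound 2 is the furthest with a higher number, also beyond the scatter. Among the measured compounds shown here, no two of the measured compounds differ in one place only, so no single step between measured compounds is available.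

Compound 4 `Cc1cc(-c2nc3cc([N+](=O)[O-])ccc3[nH]2)ccc1Cl` is not yet measured. It differs from compound 1 by chloro in place of methyl on an aromatic carbon. Within this set the lowest number belongs to compound 3, which carries two chloro groups and an iodo group on its aryl ring, while the two compounds with carbon substituents only, compound 1 and compound 2, sit higher. On that basis a modest step downward, of a size near the edge of the scatter, is expected for compound 4 relative to compound 1, that is a 1.7-fold lower number from compound 1 to compound 4 (0.24 log units; within the scatter). The estimate for compound 4 in this assay is 800 nM, with a range from 300 nM to 2500 nM.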

Compound 4, half-maximal inhibitory concentration: 2290 nM
Compound 4: the middle estimate sits 2.9-fold (0.46 log units) below what was measured, and the stated range covers the measured number.
By their numbers in this assay, from the lowest: compound 3; then compounds 1 and 4 (each within the scatter of the next); then compound 2.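

Notes on the first single-place comparison in the series: in this assay, chloro in place of methyl on an aromatic carbon, ortho to a methyl group and para to a large group, gives a 1.7-fold higher number from compound 1 to compound 4 (0.22 log units; within the scatter) and so lies within the scatter. Among the compounds shown here, at this position, with the rest of compound 1 held constant, the two groups are therefore not separated on this read-out, which the earlier compounds could not show because no two of them differed in one place only. No supporting measurement bears on why the two groups read alike here.

The compounds shown leave open whether a different group at this position, such as a methoxy group, an amine, a carboxylic acid or a longer chain, would produce a step beyond the scatter. For the compounds shown here, also open is whether the same exchange reads alike at other positions on the aryl ring or without the neighbouring methyl group, and no single step yet connects compound 2 or compound 3 to compound 1 or compound 4.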